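Sulfonylpiperidine amides: cyclobutyl to isopropyl on the sulfonyl

The compounds below may be only part of what the source reports. "The series", "measured", "known", "first", "only" and "open" are said of these compounds alone.

Measured so far:
compound 1 `CCN(CC)S(=O)(=O)c1ccc(S(=O)(=O)N2CCC[C@@H](C(=O)N3CCC(O)CC3)C2)cc1` — 4710 nM
compound 2 `O=C([C@@H]1CCCN(S(=O)(=O)c2ccc(S(=O)(=O)C3CCC3)cc2)C1)N1CCC(F)(F)CC1` — 78 nM

In a functional assay on BXPC-3 cells (Homo sapiens) for inhibition, read by MTT assay, with a stated time of 7 days (on this read-out higher numbers stand for weaker inhibition and lower numbers for stronger inhibition), compound 2 gives 78 nM and holds the lowest number of the two. Its nearest neighbour is compound 1, which in this assay gives 4710 nM; the two differ in more than one place, so the gap between them is not broken down into a single step, but it lies beyond the scatter.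

Compound 3 `CC(C)S(=O)(=O)c1ccc(S(=O)(=O)N2CCC[C@@H](C(=O)N3CCC(F)(F)CC3)C2)cc1` is not yet measured. It differs from compound 2 in one place: isopropyl in place of cyclobutyl on a sulfonyl sulfur. The remaining structure, including the difluoropiperidine amide and the shared core, is unchanged. Within the data shown here, no measured pair in the set isolates this change, so the expectation rests on the unchanged parts of compound 2 alone.

The step from compound 2 to compound 3 is expected to be small, most likely none beyond the scatter, with a slight lean toward a higher number: a 1.4-fold higher number from compound 2 to compound 3 (0.15 log units; within the scatter). Compound 3 is therefore estimated in this assay at 110 nM, with a range of 40 nM to 350 nM.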

Compound 3, half-maximal inhibitory concentration: 50 nM
For compound 3 the middle estimate is 2.2-fold (0.34 log units) above the measured one; the measured number falls inside the stated range.
By their numbers in this assay, from the lowest: compounds 3 and 2 (each within the scatter of the next); then compound 1.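

In this assay, among these compounds, the change from cyclobutyl to isopropyl on a sulfonyl sulfur gives a 1.6-fold lower number from compound 2 to compound 3 (0.19 log units; within the scatter) and is the first single-place step available. At this position, with the difluoropiperidine amide and the shared core held fixed, the four-membered non-aromatic ring of carbon is not required to keep the number in this range: isopropyl, which has no ring, cannot be told apart from cyclobutyl in this read-out. No measured property is available to account for the two groups reading alike, so this stands as an observation on compound 2 and compound 3 only.

Still open, from the compounds shown here alone, is how much this position tolerates beyond these two groups, for example a methyl group, a longer chain such as n-butyl, or a group carrying a carboxylic acid on the same sulfonyl sulfur. The amide side also remains unresolved, as no pair among these compounds changes the amide group alone, and so the separate contribution of the difluoropiperidine cannot be read.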